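Pyrazole amides at the rat glutamate receptor: compound 3

A few compounds are considered here, and "the series" means these few. Any claim that something is new, unique, unknown or untested is made for them only; others in the source may bear on it.

Measured compounds:
compound 1 `O=C(Nc1cc(-c2ccccc2)nn1-c1ccccc1)c1cccc(C(F)(F)F)c1` — 1650 nM
compound 2 `O=C(Nc1cc(-c2ccccc2)nn1-c1ccccc1)c1cccc([N+](=O)[O-])c1` — 2220 nM

In an assay on HEK293 cells for displacement of a labelled ligand from metabotropic glutamate receptor 5 (Rattus norvegicus) (a higher number here means a weaker inhibitor, a lower number a stronger inhibitor), compound 1 gives 1650 nM and compound 2 gives 2220 nM, the highest of the two numbers, with compound 1 nearest: a 1.3-fold higher number from compound 1 to compound 2 (0.13 log units; within the scatter). Compound 3 `COc1ccc(C(=O)Nc2cc(-c3ccccc3)nn2-c2ccccc2)cc1` differs from compound 2 by 4-methoxyphenyl in place of 3-nitrophenyl on a carbonyl carbon. Within the data shown here, the only measured step also swaps one group for another on this ring and stays within the scatter, so compound 3 is expected to show no step beyond the scatter, at most a slightly higher number: a 1.4-fold higher number from compound 2 to compound 3 (0.13 log units; within the scatter). Compound 3 is thus estimated at 3000 nM, between 900 nM and 10000 nM.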

Compound 3, inhibition constant: 420 nM
For compound 3 the middle estimate is 7.1-fold (0.85 log units) above the measured one; measured number outside the range, below it.
By their numbers in this assay, from the lowest: compound 3; then compounds 1 and 2 (each within the scatter of the next).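

In this assay the group on the carbonyl carbon proves able to move the number beyond the scatter: 4-methoxyphenyl in place of 3-nitrophenyl gives a 5.3-fold lower number from compound 2 to compound 3 (0.72 log units; beyond the scatter) and in place of 3-(trifluoromethyl)phenyl gives a 3.9-fold lower number from compound 1 to compound 3 (0.59 log units; beyond the scatter) while exchanging those two groups for each other stayed within the scatter. No measurement shown accounts for this stronger inhibition. Open, from the compounds shown here alone, is whether the step belongs to the methoxy group or to its place on the ring, and how 3-methoxyphenyl, or a ring carrying an amine or a hydroxyl group, would read.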